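Swapping a bromine for a pyridine ring on a shared core

The source may report more compounds than this note shows. Statements on the series, on what has been measured and on what is new or still open speak of the compounds shown alone.

Of the compounds shown here, three sharing one core have been measured in a physicochemical assay for solubility, at pH 7; on this read-out higher numbers stand for higher solubility and lower numbers for lower solubility. Compound 1, `CNC(=O)c1cc(Oc2ccc3nc(Nc4cccc(C(C)(C)C)c4)ncc3c2)ccn1`, gives only a limit of the assay, < 1000 nM. Compound 2, `CNC(=O)c1cc(Oc2ccc3nc(Nc4cccc(C(F)(F)F)c4)ncc3c2)ccn1`, likewise gives only a limit, < 1000 nM. Compound 3, `CNC(=O)c1cc(Oc2ccc3nc(Nc4ccc(Br)cc4)ncc3c2)ccn1`, also returns a limit rather than a number, < 1000 nM. All three therefore stand at the limit of < 1000 nM in this assay, at which 3 of the 3 values shown sit, and none of the steps among them can be read: a step that the two limits leave unreadable from compound 1 to compound 2, a step that the two limits leave unreadable from compound 1 to compound 3 and a step that the two limits leave unreadable from compound 2 to compound 3 all remain of unreadable size because each end sits at a limit.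

The next compound, compound 4, `CNC(=O)c1cc(Oc2ccc3nc(Nc4ccc(-c5cccnc5)cc4)ncc3c2)ccn1`, differs from compound 3 in one place: pyridin-3-yl in place of bromo on an aromatic carbon. Among the compounds with values here, no measured step speaks to this change; the three known steps only say that each compound sits at the limit, so they give neither a direction nor a size to expect. Within the data shown here, the expectation for the step from compound 3 to compound 4 in this assay is therefore an at least 1.5-fold higher number from compound 3 to compound 4 (0.17 log units; that floor lies within the scatter), drawn from no measured precedent. For compound 4 the estimated solubility in this assay is 1500 nM, expected to fall somewhere between 300 nM and 8000 nM, with a fair chance that the assay again reports only a limit.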

Compound 4, solubility: < 1000 nM
Compound 4: only a limit was reported; the forecaster's own chance of this, stated with the estimate: 50%; middle value at least 1.5-fold (0.17 log units) from the limit.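

In this assay compound 4 gives only a limit, < 1000 nM. Compound 3 also stands at a limit, so the step between compound 3 and compound 4 cannot be read: the limit of < 1000 nM in this assay, at which 4 of the 4 values shown sit.

The compounds shown leave open how soluble each one actually is, and whether pyridin-3-yl in place of bromo changes the solubility at all.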